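The source may report more compounds than this note shows. Statements on the series, on what has been measured and on what is new or still open speak of the compounds shown alone.

Measured so far in an ADME assay on microsomes from liver (Homo sapiens) for metabolic stability, tested at 2.5 uM; on this read-out higher numbers stand for fast clearance and lower numbers for slow clearance:

compound 1, `O=S(=O)(c1cc(Cl)cc(Cl)c1)c1cnc2c(F)cccc2c1-c1ccc(F)cc1`, 1.01 mL/min
compound 2, `N#Cc1cccc(S(=O)(=O)c2cnc3c(F)cccc3c2-c2ccccc2F)c1`, 0.66 mL/min

In this assay compound 2 and compound 1 lie within the scatter of each other, so the two numbers cannot be ranked. Compound 3, `N#Cc1cccc(S(=O)(=O)c2cnc3c(F)cccc3c2-c2ccc(F)cc2)c1`, is not yet measured. It differs from compound 2 by 4-fluorophenyl in place of 2-fluorophenyl on an aromatic carbon.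

Going by the values given here, no measured pair shows this change alone, so nothing in the data fixes its size. For compound 3 the expected step of a 1.2-fold higher number from compound 2 to compound 3 (0.08 log units; within the scatter) is small and not beyond the scatter, because compound 1 with 1.01 mL/min already carries 4-fluorophenyl and sits near compound 2. Compound 3 is therefore estimated at 0.8 mL/min, in the range 0.45 mL/min to 1.4 mL/min.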

Compound 3, intrinsic clearance in a liver preparation (reported as CLH), per the amount of preparation that the assay uses: 0.19 mL/min
The estimate for compound 3 lay 4.2-fold (0.62 log units) above the measured number; the measured number lies below the stated range.
By their numbers in this assay, from the lowest: compound 3; then compounds 2 and 1 (each within the scatter of the next).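

In this assay, the place of the fluorine on the phenyl group matters: 4-fluorophenyl in place of 2-fluorophenyl gives a 3.5-fold lower number from compound 2 to compound 3 (0.54 log units; beyond the scatter). With 4-fluorophenyl held fixed, 3-cyanophenyl in place of 3,5-dichlorophenyl on the sulfonyl sulfur gives a 5.3-fold lower number from compound 1 to compound 3 (0.73 log units; beyond the scatter), so the closeness of compound 1 and compound 2, which differ in both places, did not mean that each change alone is small. Nothing available explains either step. As far as these compounds go, it remains open whether the fluorine step holds with 3,5-dichlorophenyl on the sulfonyl sulfur, and how a methoxy group or an amine would read in place of that fluorine.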